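Selenium-bearing quinazoline analogues in an MCF7 growth assay

The source may hold more compounds than are shown below. What is called first, only, known or untested is meant among the compounds shown, and "the series" means these compounds.

Compound 1, `CCCCC[Se]c1nc(NCc2ccc(SC)cc2)c2ccccc2n1`: 65000 nM
Compound 2, `CSc1ccc(CNc2nc([SeH])nc3ccccc23)cc1`: > 100000 nM
Compound 3, `Nc1nc([SeH])nc2ccccc12`: > 100000 nM

Three of the four compounds considered here have been measured in a functional assay on MCF7 cells (Homo sapiens) for cytotoxicity, read by MTT assay, with a stated time of 72 h; on this read-out higher numbers stand for weaker inhibition of growth and lower numbers for stronger inhibition of growth. Compound 1 gives 65000 nM. For compound 2 the value of > 100000 nM is a limit of the assay and not a number. For compound 3 the value of > 100000 nM is likewise only a limit. Two of the three values thus sit at the limit of > 100000 nM in this assay, at which 2 of the 3 values shown sit.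

Compound 1 and compound 2 differ in one place, (pentyl in place of hydrogen on a selenium), and the step is an at least 1.5-fold lower number from compound 2 to compound 1 (0.18 log units; that floor lies within the scatter). Compound 3 and compound 2 share the selenium-bearing core, but the difference between the two cores is not broken down here.

The unmeasured compound 4, `CCCCC[Se]c1nc(N)c2ccccc2n1`, stands to compound 3 as compound 1 stands to compound 2: pentyl in place of hydrogen on a selenium. The place of the change is the same in both pairs, so this is the same kind of change.

Since the same change from compound 2 to compound 1 gave only a small step that began from a limit, compound 4 is expected to stay in the weak range, with a step of about an at least 1.1-fold lower number from compound 3 to compound 4 (0.04 log units; that floor lies within the scatter) estimated. In this assay compound 4 is therefore estimated at 90000 nM, expected to fall between 35000 nM and 250000 nM.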

Compound 4, concentration for total growth inhibition: 59500 nM
Compound 4: middle estimate off by 1.5-fold (0.18 log units), on the high side, and the stated range covers the measured number.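

In this assay, pentyl in place of hydrogen on a selenium, now on the smaller core, gives an at least 1.6-fold lower number from compound 3 to compound 4 (0.22 log units; that floor lies within the scatter). Set beside the earlier pair, the two steps can be read together only this far: the same change on two cores in this assay, an at least 1.5-fold lower number (0.18 log units; that floor lies within the scatter) from compound 2 to compound 1 and an at least 1.6-fold lower number (0.22 log units; that floor lies within the scatter) from compound 3 to compound 4; the limit leaves it open whether they differ For compound 3 the value of > 100000 nM is a limit of the assay and not a number, so the true size of this step stays unknown, and the series shows neither that the change carries over from one core to the other with a fixed size nor that its size depends on the core.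

The compounds shown leave open what a chain other than pentyl on the selenium would give, whether a shorter chain, a longer chain, or a chain ending in a carboxylic acid or an amine. They also leave open how far the compounds with hydrogen on the selenium really lie from those with pentyl, and the reading of every step here is tied to one ceiling: the limit of > 100000 nM in this assay, at which 2 of the 4 values shown sit.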